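The compounds below may be only part of what the source reports. "The series", "measured", "known", "first", "only" and "open" are said of these compounds alone.

Compound 1 `COc1ccc(CN(c2cc(OC)c(OC)c(OC)c2)S(=O)(=O)c2ccc(C)cc2)cc1` and compound 2 `COc1ccc(CN(c2cc(OC)c(OC)c(OC)c2)S(=O)(=O)c2ccccc2)cc1` share one core and differ in a single place. In a functional assay on MGC-803 cells (Homo sapiens) for inhibition, read by MTT assay, with a stated time of 48 h (a lower number here means a stronger inhibitor, a higher number a weaker inhibitor), compound 1 gives 4340 nM. Compound 2 reaches only the limit of this assay, > 50000 nM, and no number. The step of an at least 11-fold higher number from compound 1 to compound 2 (1.06 log units; beyond the scatter) is therefore read against (the limit of > 50000 nM in this assay, at which 1 of the 2 values shown sits), and its true size is open; it is known only to be large and beyond the scatter.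

Compound 3 `COc1ccc(CN(c2cc(OC)c(OC)c(OC)c2)S(=O)(=O)c2ccc(C(C)(C)C)cc2)cc1` has not yet been measured. It arises from compound 2 by tert-butyl in place of hydrogen on an aromatic carbon. Among the measured compounds shown here, the change runs opposite to the one measured step, which took a methyl off that aromatic carbon and weakened inhibition; putting a larger alkyl back in its place is thus expected to move the number downward, though how far a tert-butyl tracks a methyl cannot be told from two compounds. For the measured compounds named here, the only guide is that compound 1, carrying methyl there, gives 4340 nM.

Compound 3 is therefore expected to fall near 10000 nM, between 2000 nM and 50000 nM, an expected step of an at least 5.0-fold lower number from compound 2 to compound 3 (0.69 log units; beyond the scatter).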

Compound 3, half-maximal inhibitory concentration: 10300 nM
The estimate for compound 3 lay 1.0-fold (0.01 log units) below the measured number; measured number inside the range.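

In this assay, tert-butyl on this aromatic carbon also strengthens inhibition relative to the bare phenyl, with an at least 4.8-fold lower number from compound 2 to compound 3 (0.68 log units; beyond the scatter), so the gain is not confined to methyl. The two alkyl groups are not interchangeable, however: the change between them gives a 2.4-fold higher number from compound 1 to compound 3 (0.38 log units; beyond the scatter), which leaves compound 1, with its methyl, the strongest inhibitor of the three. Compound 2 stands at a limit and not at a number, so the true size of the gain from either group stays open: the limit of > 50000 nM in this assay, at which 1 of the 3 values shown sits.

On these data alone, with only methyl and tert-butyl in hand, it remains open how the number changes across the alkyl groups, and ethyl or isopropyl on the same carbon would be needed to tell. As far as these compounds go, whether any non-alkyl group can serve here is also open, whether a methoxy, a chlorine, an amine or a carboxylic acid.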